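Chain length series, working notes

The source may hold more compounds than are shown below. What is called first, only, known or untested is meant among the compounds shown, and "the series" means these compounds.

compound 1 `CCCCCCCCOC(=O)NC(=O)Oc1c(C(C)C)cccc1C(C)C`: in an assay on microsomes from intestine for inhibition of acyl-CoA:cholesterol acyltransferase (Oryctolagus cuniculus) (a lower number here means a stronger inhibitor, a higher number a weaker inhibitor), compound 1 gives 250 nM
compound 2 `CCCCCCCCCCOC(=O)NC(=O)Oc1c(C(C)C)cccc1C(C)C`: compound 2 gives 74 nM
compound 3 `CCCCCCCCCCC(C)OC(=O)NC(=O)Oc1c(C(C)C)cccc1C(C)C`: compound 3 gives 49 nM

Within the set, a 3.4-fold lower number from compound 1 to compound 2 (0.53 log units; beyond the scatter), the change being (ethyl in place of hydrogen on a saturated chain carbon, eight bonds along the chain from an oxygen next to a carbonyl group). Compound 3 shows the lowest number of the three, but compound 2 lies within the scatter of it; only compound 1 stands clearly higher. The difference between the core of compound 1 and the core of compound 3 is not broken down here.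

Compound 4 `CCCCCCCCCCCCC(C)OC(=O)NC(=O)Oc1c(C(C)C)cccc1C(C)C` is not yet measured. It differs from compound 3 by ethyl in place of hydrogen on a saturated chain carbon, ten or more bonds along the chain from an oxygen next to a carbonyl group. This is the same kind of change as from compound 1 to compound 2, the place differing only in how far along the chain from the oxygen next to a carbonyl group the new group sits, as the two differences above show. Given a 3.4-fold lower number from compound 1 to compound 2 (0.53 log units; beyond the scatter), a gain is expected, but a smaller one, since compound 3 already lies low with 49 nM. Compound 4 is expected to give 30 nM, estimated between 12 nM and 80 nM. That estimate means an expected step of a 1.6-fold lower number from compound 3 to compound 4 (0.21 log units; within the scatter).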

Compound 4, half-maximal inhibitory concentration: 17 nM
The estimate for compound 4 lay 1.8-fold (0.25 log units) above the measured number, and the stated range covers the measured number.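

In this assay, ethyl in place of hydrogen on a saturated chain carbon again gives a lower number, with a 2.9-fold lower number from compound 3 to compound 4 (0.46 log units; beyond the scatter). The size of the step holds from one core to the other: the same change on two cores in this assay, a 3.4-fold lower number (0.53 log units; beyond the scatter) from compound 1 to compound 2 and a 2.9-fold lower number (0.46 log units; beyond the scatter) from compound 3 to compound 4, 1.2-fold (0.07 log units) apart, within the scatter of two such steps. Within the data shown here, this rests on only two steps, with the new group at a different place along the chain in each, so it does not show whether the change would hold on any other core or how far it would extend along the chain.

The compounds shown leave open whether a longer chain would keep giving lower numbers or would level off. They also leave open how a chain carrying an amine or a carboxylic acid would behave.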